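A few compounds are considered here, and "the series" means these few. Any claim that something is new, unique, unknown or untested is made for them only; others in the source may bear on it.

Measured compounds:
compound 1 `CC(/C=C/CC(C)CCCC(C)C)=C\C(=O)OCC(C)C` — 7.69
compound 2 `CC(/C=C/CC(C)CCCC(C)(C)OC(C)C)=C\C(=O)OC(C)C` — 6.9

Of the compounds shown here, two have been measured in a physicochemical assay for lipophilicity; on this read-out lower numbers stand for lower lipophilicity and higher numbers for higher lipophilicity. Compound 1 gives 7.69, the higher of the two numbers. Within the data shown here, compound 2 gives 6.9, which lies below compound 1 by a gap beyond the usual scatter; no single-point step connects the two structures, so the pair only shows that compound 1 stands at the top of what has been measured.

The step now considered leads from compound 1 to compound 3, whose structure is `C=CCSC(=O)/C=C(C)/C=C/CC(C)CCCC(C)C`. The change is allylsulfanyl in place of isobutoxy on a carbonyl carbon. Nothing that has been measured so far bears directly on this exchange, so the expectation rests on compound 1 alone, at 7.69. The estimated step is a number 0.19 log units lower from compound 1 to compound 3 (within the scatter), a small expected change that would leave compound 3 close to compound 1 and not clearly beyond the scatter. Compound 3 is therefore expected to come out at about 7.5, within a range from 6.9 to 8.1.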

Compound 3, partition coefficient: 7.97
The estimate for compound 3 lay 0.47 log units below the measured number; low and high end bracket the measured number.
By their numbers in this assay, from the lowest: compound 2; then compounds 1 and 3 (each within the scatter of the next).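

In this assay, allylsulfanyl in place of isobutoxy on a carbonyl carbon gives a number 0.28 log units higher from compound 1 to compound 3 (within the scatter), so the two compounds cannot be told apart on this read-out. This is the first single-point step among the compounds shown, and it gives this position a direct reading that the earlier pair, which differs in more than one place, could not provide: an exchange that replaces the oxygen link with a sulfur link, takes the group from 5 heavy atoms to 4 and brings in a double bond leaves no difference beyond the scatter. No measurement at hand explains this outcome or separates the contributions of those structural differences.

The compounds shown leave open whether a saturated sulfur-linked chain, an amine or a longer alkoxy chain on the same carbonyl carbon would also stay within the scatter of compound 1. They also leave open whether allylsulfanyl would give a similar result on the core of compound 2, since a single step cannot show how far this outcome extends.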